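This account rests on a few compounds, and the source may have more. Where it says the series, first, only, none or still open, it means among the compounds named here.

Compound 3 `O=C1/C(=C/c2coc3ccccc3c2=O)N=C(c2ccccc2)N1c1ccc(S(=O)(=O)Nc2ncccn2)cc1` stands at the edge of what a functional assay on MCF7 cells (Homo sapiens) for cytotoxicity, read by sulforhodamine B assay, with a stated time of 72 h (on this read-out higher numbers stand for weaker inhibition and lower numbers for stronger inhibition), can report: compound 3 gives > 100000 nM, a limit of the assay rather than a number. Compound 1 `O=C1/C(=C/c2coc3ccccc3c2=O)N=C(c2ccccc2)N1c1ccc(S(=O)(=O)Nc2nccs2)cc1`, carrying 1,3-thiazol-2-yl on the sulfonamide nitrogen, gives 88500 nM, so the step of an at least 1.1-fold higher number from compound 1 to compound 3 (0.05 log units; that floor lies within the scatter) stays within the scatter. Compound 2 `O=C1/C(=C/c2coc3ccccc3c2=O)N=C(c2ccc(Cl)cc2)N1c1ccc(S(=O)(=O)Nc2ccccn2)cc1` gives > 100000 nM, also a limit. Compound 4 `O=C1/C(=C/c2coc3ccccc3c2=O)N=C(c2ccccc2)N1c1ccc(S(=O)(=O)Nc2ccccn2)cc1` differs from compound 3 by pyridin-2-yl in place of pyrimidin-2-yl on a sulfonamide nitrogen. Going by the values given here, the only measured step at this nitrogen, from compound 1 to compound 3, was within the scatter, and the limit of > 100000 nM in this assay, at which 2 of the 3 values shown sit, leaves little room to read a direction. Compound 4 is therefore expected to move by a step that the limit leaves unreadable from compound 3 to compound 4, nothing beyond the scatter. Compound 4 is estimated at 120000 nM, within 50000 nM to 300000 nM.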

Compound 4, half-maximal inhibitory concentration: > 100000 nM
Compound 4: only a limit was reported; the forecaster's own chance of this, stated with the estimate: 65%; the middle value does not contradict the limit.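

In this assay compound 4, with pyridin-2-yl on the sulfonamide nitrogen, gives only a limit, and the steps to it from compound 2 and compound 3 cannot be read. Going by these compounds alone, the one readable step is an at least 1.1-fold higher number from compound 1 to compound 4 (0.05 log units; that floor lies within the scatter) and adds a second ring at this nitrogen to the one step already seen there. Readings for this series now gather at one edge of the assay: the limit of > 100000 nM in this assay, at which 3 of the 4 values shown sit.

Going by these compounds, it remains open whether an acetyl or a methyl group on the sulfonamide nitrogen would leave the read-out at this limit. The same holds for an amine on the aromatic carbon that carries chloro in compound 2.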